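A Mirror Image of Compound 2

The source may hold more compounds than are shown below. What is called first, only, known or untested is meant among the compounds shown, and "the series" means these compounds.

Of the compounds shown here, three have been measured in a functional assay on HL-60 cells (Homo sapiens) for antiproliferative activity, read by MTT assay, with a stated time of 72 h; a lower number here means a stronger inhibitor, a higher number a weaker inhibitor. Compound 2 `O=C1C[C@@H]2O[C@H]3[C@H](c4ccccc4)c4ccccc4CO[C@H]3[C@@H]2O1` gives 11700 nM, level with compound 3 `Cc1ccccc1[C@H](c1ccccc1)[C@H]1O[C@@H]2CC(=O)O[C@@H]2[C@H]1O` at 11700 nM, and together they hold the highest of the three numbers. Compound 1 `O=C1C[C@H]2O[C@H](Cc3ccccc3)[C@H](OCc3ccccc3)[C@H]2O1` gives 560 nM, a much lower number and well beyond the scatter when set against compound 2.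

The next compound, compound 4 `O=C1C[C@H]2O[C@@H]3[C@@H](c4ccccc4)c4ccccc4CO[C@@H]3[C@H]2O1`, keeps everything that compound 2 is built from: the two compounds have the same atoms and bonds and differ only in configuration as drawn: 5 of 5 stereo elements differ (all stereocentres are inverted: mirror images); a stereocentre at a saturated ring carbon is drawn S in compound 2 and R in compound 4; a stereocentre at a saturated ring carbon is drawn S in compound 2 and R in compound 4; a stereocentre at a saturated ring carbon is drawn R in compound 2 and S in compound 4; a stereocentre at a saturated ring carbon is drawn R in compound 2 and S in compound 4. The two compounds have the same atoms and bonds, and all stereocentres are inverted, so they are mirror images. For the measured compounds named here, no measured pair here is a mirror-image pair, so the data give no direct guide to the size of this step. Going by the values given here, the only hint is compound 1 at 560 nM, which shows that a lower number is possible in this small set. A moderate move toward a lower number in this assay is therefore expected, though no change at all would be no surprise. The estimate means a 2.9-fold lower number from compound 2 to compound 4 (0.47 log units; beyond the scatter), an expected step with wide uncertainty. For compound 4 the estimated value is 4000 nM, expected to fall between 600 nM and 25000 nM.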

Compound 4, half-maximal inhibitory concentration: 780 nM
Compound 4: middle estimate off by 5.1-fold (0.71 log units), on the high side; measured number inside the range.
By their numbers in this assay, from the lowest: compounds 1 and 4 (each within the scatter of the next); then compounds 2 and 3 (each within the scatter of the next).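

For the compounds shown here, compound 4 is the mirror image of compound 2, and in this assay this inversion gives a 15-fold lower number from compound 2 to compound 4 (1.18 log units; beyond the scatter), the first step in this set that can be read between two measured compounds. The size of that step shows that the spatial arrangement of this scaffold matters to the read-out, even with no atom added or removed. The step can be credited to configuration alone because nothing else changes: the fact that compounds 2 and 4 differ only in the configuration as drawn.

All stereocentres invert together in this pair, so the compounds shown do not reveal whether one of them carries most of the step or several share it. On these data alone, it also remains open whether an amine or a carboxylic acid placed on the core of compound 4 would keep, raise or lower this activity.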